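Hydroxy for Chloro: Expected Cytotoxicity of Compound 4

The source may report more compounds than this note shows. Statements on the series, on what has been measured and on what is new or still open speak of the compounds shown alone.

This piece concerns a small set of compounds tested in an ADME assay on Vero cells (Chlorocebus sabaeus) for cytotoxicity, read by WST assay; on this read-out higher numbers stand for lower toxicity in this test and lower numbers for higher toxicity in this test. Compound 1 `O=c1[nH]c(Nc2cc(Cl)cc(Cl)c2)nc2cc(Cl)ccc12` is the starting point. In this assay compound 1 gives only a limit, > 25000 nM, rather than a number. Two related compounds are also on hand. Compound 2 `COC(=O)c1cccc(Nc2nc3cc(Cl)ccc3c(=O)[nH]2)c1` likewise returns a limit in this assay, > 25000 nM. Compound 3 `COc1cccc2nc(Nc3cc(Cl)cc(Cl)c3)[nH]c(=O)c12` also ends at a limit in this assay, > 25000 nM. So compound 1 stands exactly where every measured compound here stands, at the limit of > 25000 nM in this assay, at which 3 of the 3 values shown sit. No pair of these compounds differs in only one place, so no single step in this assay has been measured.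

Compound 4 `O=c1[nH]c(Nc2cc(Cl)cc(Cl)c2)nc2cc(O)ccc12` is not yet measured. It differs from compound 1 by hydroxy in place of chloro on an aromatic carbon. With every measured value sitting at the limit, there is no basis to expect a step beyond the usual scatter in either direction. The step is estimated as a step that the limit leaves unreadable from compound 1 to compound 4. Compound 4 is therefore expected to give about 30000 nM in this assay, with an expected range from 15000 nM to 60000 nM, and most likely the assay will again report only a limit.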

Compound 4, half-maximal cytotoxic concentration: > 25000 nM
Compound 4: a limit, no number (the forecaster's own chance of this, stated with the estimate: 85%); the middle value lies beyond the limit too.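

In this assay, compound 1 and compound 4 both end at a limit rather than a number, so no size can be read for hydroxy in place of chloro: the limit of > 25000 nM in this assay, at which 4 of the 4 values shown sit.

The compounds shown leave open which change to the shared core, if any, would give a readable number in this assay.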